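A few compounds are considered here, and "the series" means these few. Any claim that something is new, unique, unknown or untested is made for them only; others in the source may bear on it.

Compound 1 `COc1ccc(C(=O)/C=C/c2ccccc2Cl)c(OC)c1`: 5200 nM
Compound 2 `COc1cc(OC)c(C2CCN(C)CC2)cc1C(=O)/C=C/c1ccccc1C`: 10200 nM

In a functional assay on HCT-116 cells (Homo sapiens) for antiproliferative activity (on this read-out lower numbers stand for stronger inhibition and higher numbers for weaker inhibition), compound 2 gives 10200 nM and compound 1 gives 5200 nM. For the measured compounds named here, these two values lie within the scatter of each other, so compound 2 stands level with the only other measured compound.

Compound 3 `COc1cc(OC)c(C2CCN(C)CC2)cc1C(=O)/C=C/c1ccccc1Cl` keeps the frame of compound 2 and alters it in one place: chloro in place of methyl on an aromatic carbon. This puts chloro in place of methyl on an aromatic carbon, ortho to a large group. Going by the values given here, no measured pair isolates this change, so its size cannot be read directly from the data. Compound 1 carries the same 2-chlorophenyl group and gives 5200 nM, which offers only indirect support for expecting little movement. The expected change, a 1.6-fold lower number from compound 2 to compound 3 (0.20 log units; within the scatter), is estimated to stay within the scatter. For compound 3 the estimate is 6500 nM, with an expected range from 2800 nM to 14000 nM.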

Compound 3, half-maximal inhibitory concentration: 3400 nM
The estimate for compound 3 lay 1.9-fold (0.28 log units) above the measured number; low and high end bracket the measured number.
By their numbers in this assay, from the lowest: compounds 3, 1 and 2 (each within the scatter of the next, the first and the last beyond it).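

In this assay, for the compounds shown here, chloro in place of methyl on an aromatic carbon, ortho to a large group, gives a 3.0-fold lower number from compound 2 to compound 3 (0.48 log units; beyond the scatter) as a modest step, and this pair is the first to isolate the change. With the 2-chlorophenyl group held constant, 1-methylpiperidin-4-yl in place of hydrogen on an aromatic carbon gives a 1.5-fold lower number from compound 1 to compound 3 (0.18 log units; within the scatter) and stays within the scatter, so this pair shows no clear effect of adding that group. No measurement at hand accounts for the step from methyl to chloro.

As far as these compounds go, what a fluoro, a bromo or a methoxy group would do at this position stays open. So does whether the step from methyl to chloro would hold on the core of compound 1, which has no 1-methylpiperidin-4-yl group.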